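Swapping the Sulfonamide Heteroaryl on a Thiourea Series

A few compounds are considered here, and "the series" means these few. Any claim that something is new, unique, unknown or untested is made for them only; others in the source may bear on it.

Measured so far in a functional assay on AS49-RAW cells (Homo sapiens) for antiproliferative activity, read by sulforhodamine B assay, with a stated time of 48 h; on this read-out lower numbers stand for stronger inhibition and higher numbers for weaker inhibition:
compound 1 `O=C(Nc1ccccc1)Nc1ccc(S(=O)(=O)Nc2ccnc3cc(C(F)(F)F)ccc23)cc1` gives 24500 nM
compound 2 `Cc1noc(NS(=O)(=O)c2ccc(N/C(S)=N\c3ccnc4cc(C(F)(F)F)ccc34)cc2)c1C` gives 34000 nM
compound 3 `O=S(=O)(Nc1ccccn1)c1ccc(N/C(S)=N\c2ccnc3cc(C(F)(F)F)ccc23)cc1` gives 33500 nM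

Compound 3 sits among three numbers that all lie within the usual scatter of one another: its nearest neighbour is compound 2, and compound 1, the furthest, is still within the scatter of it. None of the three can be told apart on this read-out.

Compound 4 `COc1ncnc(NS(=O)(=O)c2ccc(N/C(S)=N\c3ccnc4cc(C(F)(F)F)ccc34)cc2)c1OC` has not yet been measured in this assay. It differs from compound 3 in one place: 5,6-dimethoxypyrimidin-4-yl in place of pyridin-2-yl on a sulfonamide nitrogen.

Among the measured compounds shown here, one measured step bears on this change. It also replaced the group on the sulfonamide nitrogen, with the thiourea and the trifluoromethyl-bearing core of compound 3 held constant, and it read a 1.0-fold lower number from compound 2 to compound 3 (0.01 log units; within the scatter). For the measured compounds named here, that single step suggests the sulfonamide substituent can be exchanged for another heteroaryl without moving the number, though it is only one example and the incoming 5,6-dimethoxypyrimidin-4-yl is larger than either group already tried.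

The expectation for compound 4 is therefore a step of a 1.0-fold lower number from compound 3 to compound 4 (0.02 log units; within the scatter), that is, no movement beyond the scatter. Compound 4 is estimated at 32000 nM, with a range from 13000 nM to 80000 nM.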

Compound 4, half-maximal inhibitory concentration: 81800 nM
For compound 4 the middle estimate is 2.6-fold (0.41 log units) below the measured one; the measured number lies above the stated range.
By their numbers in this assay, from the lowest: compounds 1, 3 and 2 (each within the scatter of the next); then compound 4.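

In this assay the group on the sulfonamide nitrogen turns out not to be freely exchangeable: 5,6-dimethoxypyrimidin-4-yl in place of pyridin-2-yl gives a 2.4-fold higher number from compound 3 to compound 4 (0.39 log units; beyond the scatter), and in place of 3,4-dimethyl-1,2-oxazol-5-yl it gives a 2.4-fold higher number from compound 2 to compound 4 (0.38 log units; beyond the scatter). Among the compounds shown here, the earlier exchange at this position, a 1.0-fold lower number from compound 2 to compound 3 (0.01 log units; within the scatter), showed no response, so these two modest steps, which share compound 4 as their end point, are the first sign that the number can move here at all, and the entering group is the one with more heavy atoms and hydrogen-bond acceptors than pyridin-2-yl. Nothing available on these compounds accounts for the rise.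

The compounds shown leave open whether the change follows from the pyrimidine ring itself or from its two methoxy groups, which a plain pyrimidin-4-yl or a ring with a single methoxy group would separate. They also leave open how the number would respond to a plain phenyl on the sulfonamide nitrogen, or to a hydrogen alone in that place.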